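The compounds below may be only part of what the source reports. "The series", "measured", "known", "first", "only" and "open" are said of these compounds alone.

For the measured compounds named here, in a physicochemical assay for lipophilicity, read by LC-MS, using the shake flask method, at pH 7.4 (a lower number here means a more polar compound, a higher number a more lipophilic compound), compound 2 `CS(=O)(=O)NC(=O)c1cc(C2CC2)c(OCC2CCN(Cc3ccccc3)CC2)cc1F` gives 0.3, the lower of the two numbers so far, and compound 1 `CS(=O)(=O)NC(=O)c1cc(C2CC2)c(OCC2CCN(C(=O)c3cc(Cl)cc(Cl)c3)CC2)cc1F` gives 0.9. Compound 3 `CS(=O)(=O)NC(=O)c1cc(C2CC2)c(OCC2CCN(Cc3cc(Cl)cc(Cl)c3)CC2)cc1F` differs from compound 2 by carrying 3,5-dichlorophenyl in place of phenyl on a saturated chain carbon bound to an amine nitrogen in a ring. Going by the values given here, only one measured step bears on this change: a number 0.60 log units lower from compound 1 to compound 2 (beyond the scatter). That modest step removed the chlorines and the carbonyl together, so it cannot separate their shares. Restoring the chlorines alone is therefore expected to reverse that drop, with an estimated step of a number 0.80 log units higher from compound 2 to compound 3 (beyond the scatter). For compound 3 the estimate is 1.1, with an expected range from 0.6 to 1.7.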

Compound 3, distribution coefficient: 2
The estimate for compound 3 lay 0.90 log units below the measured number; the measured number lies above the stated range.
By their numbers in this assay, from the lowest: compound 2; then compound 1; then compound 3.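

In this assay, for the compounds shown here, swapping phenyl for 3,5-dichlorophenyl on a saturated chain carbon bound to an amine nitrogen in a ring gives a number 1.70 log units higher from compound 2 to compound 3 (beyond the scatter), which isolates the chlorines for the first time. With the chlorines kept, 3,5-dichlorobenzyl in place of (3,5-dichlorophenyl)carbonyl gives a number 1.10 log units higher from compound 1 to compound 3 (beyond the scatter), so the carbonyl and the chlorines, combined in the earlier step, pull in opposite directions here. Nothing available explains either step. Still open, as far as these compounds go, is how a benzyl carrying a single chlorine, or two trifluoromethyl groups instead of the chlorines, would read.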